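A few compounds are considered here, and "the series" means these few. Any claim that something is new, unique, unknown or untested is made for them only; others in the source may bear on it.

Measured in a functional assay on MCF7 cells (Homo sapiens) for inhibition, read by CCK-8 assay, with a stated time of 48 h; on this read-out higher numbers stand for weaker inhibition of growth and lower numbers for stronger inhibition of growth:
Compound 1 `Cc1ccccc1Nc1nc(Nc2ccccc2)ncc1Cl`: > 100000 nM, a limit of the assay
Compound 2 `Cc1ccccc1Nc1nc(NCc2ccco2)ncc1Cl`: > 100000 nM, a limit of the assay
Compound 3 `Cc1ccccc1Nc1nc(Nc2ccccn2)ncc1Cl`: 31400 nM

Compound 3 is the only one of the three with a true number, at 31400 nM. The other two compounds share (the limit of > 100000 nM in this assay, at which 2 of the 3 values shown sit).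

Compound 4 `Cc1ccccc1Nc1nc(Nc2cc(Cl)ccn2)ncc1Cl` differs from compound 3 in one place, pyridin-2-yl to 4-chloropyridin-2-yl: chloro in place of hydrogen on an aromatic carbon.

Among the compounds with values here, two measured steps bear on this change, and only indirectly. Each swaps the whole group on the nitrogen, giving an at least 3.1-fold lower number from compound 1 to compound 3 (0.50 log units; beyond the scatter) and an at least 3.1-fold lower number from compound 2 to compound 3 (0.50 log units; beyond the scatter). Within the data shown here, neither adds a chloro, so no measured step gives the size of this change directly. In this assay only a small step is therefore expected, leaning slightly towards a lower number, and a wide range is needed. A return to the limit of the assay remains possible.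

The expected change is a 1.6-fold lower number from compound 3 to compound 4 (0.20 log units; within the scatter). Compound 4 is estimated at 20000 nM, with an expected range from 5000 nM to 80000 nM.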

Compound 4, concentration for 50% growth inhibition: > 100000 nM
Compound 4: no number, only a limit; the forecaster's own chance of this, stated with the estimate: 15%; middle value at least 5.0-fold (0.69 log units) from the limit.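

In this assay, chloro in place of hydrogen on an aromatic carbon, opposite the ring nitrogen, is the first change shown on the pyridin-2-yl group itself, and it gives an at least 3.1-fold higher number from compound 3 to compound 4 (0.50 log units; beyond the scatter). Compound 4 gives > 100000 nM, which is a limit of the assay and not a number, so this change has a lower bound on its size but no measured size. The steps from compound 1 and from compound 2 to compound 4 cannot be read, and among the four compounds only compound 3 keeps a true number: the limit of > 100000 nM in this assay, at which 3 of the 4 values shown sit.

From the compounds shown here alone, whether fluoro, methoxy or an amine at this same place would keep a number stays open. So does whether chloro at another place on the pyridin-2-yl group would have the same result.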